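Methoxy in place of hydroxy on the pendant aryl ring

The source may hold more compounds than are shown below. What is called first, only, known or untested is meant among the compounds shown, and "the series" means these compounds.

Measured so far:
compound 1 `N#CC1=C(N)N(c2ccc(S(N)(=O)=O)cc2)C2=C(C(=O)CCC2)C1c1ccc(O)cc1` — 90%
compound 2 `COc1ccc(C2C(C#N)=C(N)N(c3ccc(S(N)(=O)=O)cc3)C3=C2C(=O)CCC3)cc1` — 30%
compound 3 `N#CC1=C(N)N(c2ccc(S(N)(=O)=O)cc2)C2=C(C(=O)CCC2)C1c1c(O)ccc2ccccc12` — 0%

All three share one core and differ only in the aryl group on the saturated ring carbon. In a functional assay on Ehrlich cells (Mus musculus) for antiproliferative activity, read by trypan blue exclusion, with a stated time of 2 h, tested at 10 ug/mL (a lower number here means a weaker effect, a higher number a stronger effect of the compound at the concentration tested), compound 1 gives 90%. The change from compound 1 to compound 2 is methyl in place of hydrogen on an oxygen on an aromatic ring, and it made a step of a number 60 percentage points lower from compound 1 to compound 2 (beyond the scatter). The cores of compound 1 and compound 3 differ by 2-hydroxynaphthalen-1-yl in place of 4-hydroxyphenyl on a saturated ring carbon, with a step of a number 90 percentage points lower from compound 1 to compound 3 (beyond the scatter); compound 3 also sits a number 30 percentage points lower from compound 2 to compound 3 (beyond the scatter) from compound 2 and is the weakest of the three in this assay.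

Compound 4 `COc1ccc2ccccc2c1C1C(C#N)=C(N)N(c2ccc(S(N)(=O)=O)cc2)C2=C1C(=O)CCC2` is not yet measured. It differs from compound 3 by methyl in place of hydrogen on an oxygen on an aromatic ring, the same change as from compound 1 to compound 2, at a place described in identical words. Compound 3 gives 0% in this assay, so there is no room for a downward step of the earlier size. Compound 4 is expected to stay low, with an estimated step of a number 3 percentage points higher from compound 3 to compound 4 (within the scatter) resting on compound 3 giving 0% and on the earlier step of a number 60 percentage points lower from compound 1 to compound 2 (beyond the scatter). The estimate for compound 4 in this assay is 3%, between 0% and 20%.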

Compound 4, a percentage reported as activity, at one concentration (the size of the read-out at that concentration, not a potency): 40%
Compound 4: middle estimate off by 37 percentage points, on the low side; the measured number lies above the stated range.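

Methyl in place of hydrogen on the oxygen gives a number 40 percentage points higher from compound 3 to compound 4 (beyond the scatter) in this assay, and this step does not carry over from the earlier core, since the two steps run in opposite directions: the same change on two cores in this assay, a number 60 percentage points lower (beyond the scatter) from compound 1 to compound 2 and a number 40 percentage points higher (beyond the scatter) from compound 3 to compound 4, 100 percentage points apart, beyond the scatter of two such steps

Among the two methoxy compounds, the aryl exchange gives a number 10 percentage points higher from compound 2 to compound 4 (within the scatter), so compound 2 and compound 4 are not separated in this read-out, whereas the exchange that also adds the methyl gives a number 50 percentage points lower from compound 1 to compound 4 (beyond the scatter). These two pairs show that neither the size nor the direction of the hydroxy to methoxy change can be transferred between the 4-hydroxyphenyl and 2-hydroxynaphthalen-1-yl series, but they give no cause for this and no rule for other aryl groups, and each number is an effect at one concentration, not a potency.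

From the compounds shown here alone, it remains open how an ethoxy group, with its longer chain on the same oxygen, would behave on either aryl group. The same is true of an amine in place of the hydroxy group.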